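The source may hold more compounds than are shown below. What is called first, only, known or untested is meant among the compounds shown, and "the series" means these compounds.

Series notes. Among the compounds with values here, compound 1 `O=C1C(Nc2ccccc2F)=CC(=O)c2c1nc1n2[C@H]2OC[C@@H](O)[C@H]2OC1` is the only member with a number in a functional assay on ECa-109 cells for inhibition, with ECa-109 cell line (Homo sapiens) as the target, read by sulforhodamine B assay; on this read-out lower numbers stand for stronger inhibition and higher numbers for weaker inhibition: compound 1 gives 2660 nM. Compound 2 `O=C1C=C(NC2CCCC2)C(=O)c2c1nc1n2[C@H]2OC[C@@H](O)[C@H]2OC1` is the other measured member. In this assay, within the data shown here, compound 2 gives > 16000 nM, which is a limit of the assay and not a number; the series therefore holds only one number and (the limit of > 16000 nM in this assay, at which 1 of the 2 values shown sits). Among the measured compounds shown here, no pair of measured compounds differs in a single place, so no measured step is available to lean on.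

Compound 3 `CCOc1ccc(NC2=CC(=O)c3c(nc4n3[C@H]3OC[C@@H](O)[C@H]3OC4)C2=O)cc1` differs from compound 1 by 4-ethoxyphenyl in place of 2-fluorophenyl on an amine nitrogen. For the measured compounds named here, with no measured step on this amine nitrogen, the expectation is a step from compound 1 to compound 3 of a 1.1-fold higher number from compound 1 to compound 3 (0.05 log units; within the scatter), not beyond the usual scatter in either direction. Compound 3 is therefore expected to give about 3000 nM in this assay, with a range of 1000 nM to 10000 nM; some chance remains that compound 3 only reaches a limit.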

Compound 3, half-maximal inhibitory concentration: > 4000 nM
Compound 3: no number, only a limit (the forecaster's own chance of this, stated with the estimate: 15%); middle value at least 1.3-fold (0.12 log units) away from the limit.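

In this assay compound 3 gives > 4000 nM, which is a limit of the assay and not a number. Within the data shown here, replacing 2-fluorophenyl with 4-ethoxyphenyl on the amine nitrogen gives the first step that can be read at this position, and it can be read only as a floor: an at least 1.5-fold higher number from compound 1 to compound 3 (0.17 log units; that floor lies within the scatter). The 4-ethoxyphenyl change therefore gives no measured gain on compound 1, and the series now holds two limits against its one number: the limit of > 4000 nM in this assay, at which 1 of the 3 values shown sits.

From the compounds shown here alone, the true size of the step stays open, as does any ranking of aryl against cycloalkyl groups on this nitrogen. A 4-fluorophenyl or a 2-ethoxyphenyl on the same amine nitrogen would show whether the group itself or its numbered place on the phenyl ring matters more.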